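This account rests on a few compounds, and the source may have more. Where it says the series, first, only, none or still open, it means among the compounds named here.

Compound 1 `COc1ccc(C(=O)c2ccc3c(c2)C(n2ccccc2=O)=CC(C)(C)O3)cc1` — 6.15
Compound 2 `Cc1ccccc1C(=O)c1ccc2c(c1)C(n1ccccc1=O)=CC(C)(C)O2` — 6.83
Compound 3 `CC1(C)C=C(n2ccccc2=O)c2cc(C(=O)c3c(F)cccc3F)ccc2O1` — 6.97

These three compounds were measured in a functional assay (aorta) with Rattus norvegicus as the target; on this read-out higher numbers stand for higher potency (the scale is a negative logarithm) and lower numbers for lower potency. Compound 2 stands second highest of the three numbers: compound 3 is its nearest neighbour, a number 0.14 log units higher from compound 2 to compound 3 (within the scatter), a gap within the scatter, while compound 1 is furthest off, as a number 0.68 log units higher from compound 1 to compound 2 (beyond the scatter) shows a gap beyond the scatter. Compound 4 `CC1(C)C=C(n2ccccc2=O)c2cc(C(=N)S)ccc2O1` has not yet been measured. Relative to compound 2 the change is a group of 3 heavy atoms (1 carbon, 1 nitrogen, 1 sulfur; no ring) in place of a group of 9 heavy atoms (8 carbon, 1 oxygen; one six-membered aromatic ring of carbon only), on an aromatic carbon. Every measured step exchanged one ring on the carbonyl carbon for another: a number 0.68 log units higher from compound 1 to compound 2 (beyond the scatter) and a number 0.82 log units higher from compound 1 to compound 3 (beyond the scatter) were modest gains beyond the scatter, and a number 0.14 log units higher from compound 2 to compound 3 (within the scatter) stayed within it. None of them removed the carbonyl-bearing ring altogether, so they offer no direct guide for compound 4. The expected step is therefore a number 0.83 log units lower from compound 2 to compound 4 (beyond the scatter), a small fall with a wide range that mirrors the lack of any comparable measured step. Compound 4 is expected to give about 6 in this assay, between 5 and 7.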

Compound 4, logarithm of the reciprocal of the active concentration, log(1/C): 6.21
Beside the measured number, compound 4's estimate is 0.21 log units below it; low and high end bracket the measured number.
By their numbers in this assay, from the lowest: compounds 1 and 4 (each within the scatter of the next); then compounds 2 and 3 (each within the scatter of the next).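

Swapping the whole (2-methylphenyl)carbonyl group for a small group with no ring gives, in this assay, a number 0.62 log units lower from compound 2 to compound 4 (beyond the scatter). The read-out nevertheless stays well measurable without any ring at this position, since compound 4 at 6.21 sits within the scatter of compound 1 at 6.15, so among the compounds shown a suitable ring on the carbonyl raises the number but is not needed for activity. Nothing shown explains the fall.

A single ring-free group cannot show whether its sulfur, its nitrogen or simply its small size sets the value of compound 4. Placing an amine, a carboxylic acid or a longer chain on the same aromatic carbon of the shared core would begin to answer that, and how such groups compare remains open.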